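The source may report more compounds than this note shows. Statements on the series, on what has been measured and on what is new or still open speak of the compounds shown alone.

Measured so far:
- compound 1, `CCc1ccccc1NC(=O)N[C@H](C)c1ccccc1`: 101%
- compound 2, `CCc1cccc(NC(=O)N[C@H](C)c2ccccc2)c1`: 97%
- compound 3, `CC(C)c1ccccc1NC(=O)N[C@H](C)c1ccccc1`: 103%

All three were tested in an ADME assay on the whole organism with Oryza sativa as the target, tested at 0.1 uM; on this read-out lower numbers stand for a stronger effect and higher numbers for a weaker effect at the one concentration tested. Compound 1 and compound 3 share one core, and compound 3 is made from compound 1 by methyl in place of hydrogen on a saturated chain carbon bound to an aromatic carbon and a saturated chain carbon. In this assay this change gave a number 2 percentage points higher from compound 1 to compound 3 (within the scatter), so the two compounds cannot be told apart by this read-out. Compound 2 has a core built from the same atoms as compound 1, joined differently; the difference between the two cores is not broken down here. In this assay compound 2 gives 97%, which sits close to what compound 1 and compound 3 gave.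

Compound 4, `CC(C)c1cccc(NC(=O)N[C@H](C)c2ccccc2)c1`, has not yet been measured in this assay. It arises from compound 2 by methyl in place of hydrogen on a saturated chain carbon bound to an aromatic carbon and a saturated chain carbon. Among the measured compounds shown here, this is the same change as the one from compound 1 to compound 3, made at the same place, only on the other core. With just one earlier example of this change, the expectation for compound 4 must rest on it. Since the earlier step was a number 2 percentage points higher from compound 1 to compound 3 (within the scatter), the step to compound 4 is expected to be a number 2 percentage points higher from compound 2 to compound 4 (within the scatter). On this basis compound 4 is estimated to give 99% in this assay, with a likely range from 90% to 108%.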

Compound 4, a percentage reported as activity, at one concentration (the size of the read-out at that concentration, not a potency): 74%
Compound 4: the middle estimate sits 25 percentage points above what was measured; the whole stated range lies above it.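

In this assay, going from ethyl to isopropyl gave a number 23 percentage points lower from compound 2 to compound 4 (beyond the scatter), a clear gain in effect on this read-out, and the same change did not behave alike on the two cores: the same change on two cores in this assay, a number 2 percentage points higher (within the scatter) from compound 1 to compound 3 and a number 23 percentage points lower (beyond the scatter) from compound 2 to compound 4, 25 percentage points apart, beyond the scatter of two such steps In this small series, then, the step seen on one core was a poor guide to the step on the other, and the outcome of this change has to be judged core by core rather than assumed to transfer. Among the compounds shown here, what the result does not show is why the two cores part ways, or whether either step is typical of its core, since each core offers only a single pair and two steps cannot establish a general rule.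

The compounds shown carry only ethyl and isopropyl at this place, so it stays open whether a longer chain such as propyl, or a tert-butyl group, would extend the drop in the number seen on the core of compound 2 or leave the number unchanged, as on the core of compound 1. On these data alone, how a methoxy group or a chlorine atom would behave on each of the two cores also remains open.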